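Losing the 3-methylbut-2-en-1-yl chain from compound 1

A few compounds are considered here, and "the series" means these few. Any claim that something is new, unique, unknown or untested is made for them only; others in the source may bear on it.

In a functional assay on A549 cells (Homo sapiens) for inhibition, read by MTT assay, with a stated time of 72 h (a higher number here means a weaker inhibitor, a lower number a stronger inhibitor), compound 1 (`COc1cc(O)c(CC=C(C)C)c(O)c1C(=O)/C=C/c1ccc(O)c(O)c1`) gives 16100 nM. Compound 2 (`COc1ccccc1/C=C/C(=O)c1c(OC)cc(O)c(CC=C(C)C)c1O`) gives 12500 nM, and compound 3 (`COc1cc(O)c(CC=C(C)C)c(O)c1C(=O)/C=C/c1cccc([N+](=O)[O-])c1`) gives 15000 nM. The three form one group, and compound 1 does not stand apart from the other two: the measured steps are a 1.3-fold lower number from compound 1 to compound 2 (0.11 log units; within the scatter), a 1.1-fold lower number from compound 1 to compound 3 (0.03 log units; within the scatter) and a 1.2-fold higher number from compound 2 to compound 3 (0.08 log units; within the scatter).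

Compound 4 (`COc1cc(O)cc(O)c1C(=O)/C=C/c1ccc(O)c(O)c1`) carries hydrogen in place of 3-methylbut-2-en-1-yl on an aromatic carbon, ortho to two hydroxy groups: hydrogen in place of 3-methylbut-2-en-1-yl on an aromatic carbon. The three measured steps all replace the phenyl group on the double-bonded chain carbon, elsewhere in the molecule. They bear on this change only indirectly, showing how little this assay moved across those replacements. All three measured compounds keep the 3-methylbut-2-en-1-yl chain, so the effect of removing it has not been measured.

A moderate move to a higher number is expected, as a judgement and not a measured trend, and a result within the scatter of compound 1 remains possible. The estimated change in this assay is a 1.9-fold higher number from compound 1 to compound 4 (0.27 log units; within the scatter). For compound 4 the estimated value is 30000 nM, with an expected range of 13000 nM to 70000 nM.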

Compound 4, half-maximal inhibitory concentration: 11800 nM
Compound 4: the middle estimate sits 2.5-fold (0.41 log units) above what was measured; the measured number lies below the stated range.
By their numbers in this assay, from the lowest: compounds 4, 2, 3 and 1 (each within the scatter of the next).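

In this assay, hydrogen in place of 3-methylbut-2-en-1-yl gives a 1.4-fold lower number from compound 1 to compound 4 (0.13 log units; within the scatter). Among these compounds, this is the first reading at the aromatic carbon ortho to two hydroxy groups, and this change, like the earlier replacements of the phenyl group on the double-bonded chain carbon, stays within the scatter. With the 3,4-dihydroxyphenyl group held constant, the 3-methylbut-2-en-1-yl chain is therefore not needed to keep the number at the level of compound 1, and nothing at hand explains why the step is so small.

The compounds shown span only hydrogen and 3-methylbut-2-en-1-yl at this position, so it remains open whether a longer chain, an amine or a carboxylic acid on the same aromatic carbon would move the number beyond the scatter. Among the compounds shown here, it is also open whether the chain can be lost with the same small step when the 2-methoxyphenyl group of compound 2 or the 3-nitrophenyl group of compound 3 is present, since the single pair here covers only the 3,4-dihydroxyphenyl case.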